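The source may report more compounds than this note shows. Statements on the series, on what has been measured and on what is new or still open speak of the compounds shown alone.

Of the compounds shown here, two share a core and have been tested in a functional assay on HepG2 cells (Homo sapiens) for cytotoxicity, read by MTT assay, with a stated time of 72 h; on this read-out lower numbers stand for stronger inhibition and higher numbers for weaker inhibition. Compound 1, `COc1ccc(-c2ccnc(C(=O)Nc3ccc(Oc4ccnc5[nH]ccc45)cc3)c2)cc1`, gives in this assay a value of 11700 nM. Compound 2, `Cc1cccc(-c2ccnc(C(=O)Nc3ccc(Oc4ccnc5[nH]ccc45)c(F)c3)c2)c1`, gives in this assay a value of 11200 nM. These two numbers sit so close together that the difference between them falls inside the usual scatter of repeated measurements, so neither compound can be called the stronger one on this evidence; compound 2 simply stands beside compound 1 as one of two nearly identical readings.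

Compound 3, `Cc1ccc(-c2ccnc(C(=O)Nc3ccc(Oc4ccnc5[nH]ccc45)c(F)c3)c2)c(C)c1`, has not yet been measured. It differs from compound 2 in a single place: 2,4-dimethylphenyl in place of 3-methylphenyl on an aromatic carbon. Within the data shown here, since no measured pair in this set shows what such a change does, there is no step to lean on, and the expectation is that the change moves the number little, if at all, beyond the scatter.

For compound 3 the step of a 1.1-fold lower number from compound 2 to compound 3 (0.05 log units; within the scatter) is the expected outcome. Compound 3 is therefore estimated at 10000 nM in this assay, with a likely range from 4000 nM to 25000 nM.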

Compound 3, half-maximal inhibitory concentration: 13300 nM
Compound 3: the middle estimate sits 1.3-fold (0.12 log units) below what was measured, within the range that was stated.
By their numbers in this assay, from the lowest: compounds 2, 1 and 3 (each within the scatter of the next).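

Replacing 3-methylphenyl with 2,4-dimethylphenyl on the aromatic carbon opposite the ring nitrogen gives, in this assay, a 1.2-fold higher number from compound 2 to compound 3 (0.07 log units; within the scatter). Among these compounds, this is the first step in the set that can be read at this position, and it shows that moving from one methyl group to two, with their placement on the phenyl ring also altered, produces no effect that can be told apart from the scatter of the assay, so for these two hydrocarbon groups the position gives no sign of being sensitive to the change. No measurement is available that would account for this result.

From the compounds shown here alone, whether an amine or a carboxylic acid on this phenyl ring, or a longer alkyl chain in place of a methyl group, would move the number beyond the scatter remains open. Among the compounds shown here, the single step also cannot separate the effect of the methyl group that was added from the effect of the new substitution pattern, since both change together between compound 2 and compound 3.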